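Furan to fluoropyridine on a diaryl amine: an expectation

The source may hold more compounds than are shown below. What is called first, only, known or untested is meant among the compounds shown, and "the series" means these compounds.

The measured compounds and their values in a functional assay on PC-3 cells (Homo sapiens) for antiproliferative activity, read by CCK-8 assay, with a stated time of 6 days (on this read-out lower numbers stand for stronger inhibition and higher numbers for weaker inhibition), are:
compound 1, `Cc1noc(C)c1-c1cccc(Oc2ccc(C#N)c(C(F)(F)F)c2)c1`, "not determined" (no result reported);
compound 2, `CCN(c1ccc(C#N)c(Cl)c1)c1cc(-c2ccoc2)ccc1C`, > 30000 nM;
compound 3, `Cn1nccc1-c1cccc2c1CCCN2c1ccc(C#N)c(C(F)(F)F)c1`, 9800 nM.

Compound 2 sits at a limit of this assay, not at a number. Of the three entries it is the only one reported as a limit, while compound 1 carries no result at all, so the one number shown belongs to compound 3. The account follows the step from compound 2 to the unmeasured compound 4, `CCN(c1ccc(C#N)c(Cl)c1)c1cc(-c2ccc(F)nc2)ccc1C`. The change is 6-fluoropyridin-3-yl in place of furan-3-yl on an aromatic carbon.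

For the measured compounds named here, no measured pair that differs in one place is available here, so the size of this step cannot be read from a neighbour. Compound 2 is held at the limit (the limit of > 30000 nM in this assay, at which 1 of the 3 values shown sits), and nothing in the data says whether a 6-fluoropyridin-3-yl in place of the furan-3-yl moves the value in either direction. Compound 4 is therefore expected near where compound 2 stands, with a step of an at least 1.5-fold lower number from compound 2 to compound 4 (0.17 log units; that floor lies within the scatter) at most, and its value is estimated at 20000 nM, between 5000 nM and 60000 nM, with a fair chance that this assay again reports only a limit.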

Compound 4, half-maximal inhibitory concentration: > 30000 nM
Compound 4 gave a limit, no number; the forecaster's own chance of this, stated with the estimate: 50%; middle value at least 1.5-fold (0.17 log units) from the limit.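

In this assay, compound 2 and compound 4 both stand at a limit rather than at a number, so no step between them can be read: the limit of > 30000 nM in this assay, at which 2 of the 4 values shown sit.

The compounds shown leave open whether 6-fluoropyridin-3-yl in place of furan-3-yl changes the value at all.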